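The source may hold more compounds than are shown below. What is called first, only, known or untested is meant among the compounds shown, and "the series" means these compounds.

Measured so far:
Compound 1 `COC(=O)N(C)c1c(N)nc(-n2nc(Cc3c(F)ccc(F)c3F)c3ccccc32)nc1N` — 270 nM
Compound 2 `COC(=O)N(C)c1c(N)nc(-n2nc(Cc3ccccc3F)c3ccccc32)nc1N` — 310 nM
Compound 3 `CC1(C)C(=O)Nc2nc(-n3nc(Cc4ccccc4F)c4cc(Cl)ccc43)nc(N)c21` — 18000 nM

All three numbers come from an assay on CHO cells for activation of soluble guanylate cyclase alpha1/beta1 complex (Homo sapiens), read by cGMP accumulation; a higher number here means that more compound is needed for the effect, a lower number that less compound is needed. Compound 1 and compound 2 share a core and differ only by 2,3,6-trifluorophenyl in place of 2-fluorophenyl on a saturated chain carbon bound to an aromatic carbon; that change gave a 1.1-fold lower number from compound 2 to compound 1 (0.06 log units; within the scatter), so the two are indistinguishable here. Compound 3 is built on a different core; the difference between the two cores is not broken down here. Its value stands well above those of compound 1 and compound 2, beyond the scatter in both cases.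

Compound 4 `CC1(C)C(=O)Nc2nc(-n3nc(Cc4c(F)ccc(F)c4F)c4cc(Cl)ccc43)nc(N)c21` has not been measured. It keeps the core of compound 3 and differs from it by 2,3,6-trifluorophenyl in place of 2-fluorophenyl on a saturated chain carbon bound to an aromatic carbon, the same change that separates compound 2 from compound 1, made at the same place. The step from compound 3 to compound 4 in this assay is expected to be a 1.1-fold lower number from compound 3 to compound 4 (0.05 log units; within the scatter), essentially flat, because the identical change once gave a 1.1-fold lower number from compound 2 to compound 1 (0.06 log units; within the scatter). Compound 4 is therefore estimated at about 16000 nM, plausibly between 6000 nM and 45000 nM.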

Compound 4, half-maximal effective concentration: 7300 nM
Estimate against measurement, compound 4: 2.2-fold (0.34 log units) above; the measured number falls inside the stated range.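

In this assay, 2,3,6-trifluorophenyl in place of 2-fluorophenyl on a saturated chain carbon bound to an aromatic carbon gave a 2.5-fold lower number from compound 3 to compound 4 (0.39 log units; beyond the scatter). Set beside the same change on the other core, the two steps cannot be told apart: the same change on two cores in this assay, a 1.1-fold lower number (0.06 log units; within the scatter) from compound 2 to compound 1 and a 2.5-fold lower number (0.39 log units; beyond the scatter) from compound 3 to compound 4, 2.1-fold (0.33 log units) apart, within the scatter of two such steps. This shows that the change carried from one core to the other with no detectable difference in the size of its effect, but two pairs do not show that the effect is identical on both cores or that it would hold on any further core in the series.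

The compounds shown leave open how the same change would behave on a third core. They also leave open whether a trifluoromethyl or a nitrile in place of the fluorines, or a longer chain in place of the saturated chain carbon, would carry from one core to another in the same way.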